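Growth inhibition notes: from compound 3 to compound 4

A few compounds are considered here, and "the series" means these few. Any claim that something is new, unique, unknown or untested is made for them only; others in the source may bear on it.

In a functional assay on Caco-2 cells (Homo sapiens) for inhibition, read by MTT assay, with a stated time of 48 h, tested at 10 uM (a lower number here means less inhibition of growth, a higher number more inhibition of growth at the concentration tested), compound 1 `Cc1cc(=O)c2c(O)cc(OCc3ccccc3)c([C@H]3CCN(C)C[C@H]3O)c2o1` gives 18% and compound 2 `Cc1cc(=O)c2c(O)c(CN(C(C)C)C(C)C)c(O)c([C@H]3CCN(C)C[C@H]3O)c2o1` gives 22% of growth inhibition. Compound 3 `Cc1oc2c([C@H]3CCN(C)C[C@H]3O)c(O)cc(O)c2c(=O)c1C(O)c1ccc([N+](=O)[O-])cc1` gives 5% and stands lowest of the three, beyond the scatter from both of the others.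

Compound 4 `Cc1oc2c([C@H]3CCN(C)C[C@H]3O)c(O)cc(O)c2c(=O)c1C(O)c1c(F)cccc1Cl` is still unmeasured. It carries 2-chloro-6-fluorophenyl in place of 4-nitrophenyl on a saturated chain carbon bound to an aromatic carbon and an oxygen on a saturated carbon and is otherwise the same structure as compound 3. Within the data shown here, no measured pair differs in one place only, so the data offer no direct guide to this change.

With compound 3 at 5% little room remains downward, so any movement in this assay is expected to be upward, and no step beyond the scatter is expected. The expected step of a number 5 percentage points higher from compound 3 to compound 4 (within the scatter) stays small. For compound 4 the estimate is 10% with an expected range from 0% to 24% (still to be tested).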

Compound 4, percent growth inhibition at one concentration: 18%
Estimate against measurement, compound 4: 8 percentage points below; low and high end bracket the measured number.
By their numbers in this assay, from the lowest: compound 3; then compounds 1, 4 and 2 (each within the scatter of the next).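

In this assay the aryl group on this saturated chain carbon, bound to an aromatic carbon and an oxygen on a saturated carbon, proves able to shift the read-out: 2-chloro-6-fluorophenyl in place of 4-nitrophenyl gives a number 13 percentage points higher from compound 3 to compound 4 (beyond the scatter) in the only single-place comparison shown. The low number of compound 3 therefore does not follow from the rest of the structure alone, but changes with this aryl group. No measured evidence bears on why the step occurs.

This single pair cannot separate the loss of the nitro group from the entry of chlorine and fluorine. From the compounds shown here alone, how an unsubstituted phenyl, a 4-chlorophenyl or a pyridine ring on the same carbon would read remains open, as does the effect of an amine in place of its hydroxy group.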